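Extending the chain on the aromatic nitrogen

The source may report more compounds than this note shows. Statements on the series, on what has been measured and on what is new or still open speak of the compounds shown alone.

Compound 1, `Cc1[nH]c2ccc(Br)cc2c1C1=CCNCC1`, gives 10 nM in an assay on HEK293 cells for displacement of a labelled ligand from 5-hydroxytryptamine receptor 6 (Homo sapiens), read by scintillation counting, with a stated time of 1 h; on this read-out lower numbers stand for stronger inhibition and higher numbers for weaker inhibition.
Compound 2, `Cc1c(C2=CCNCC2)c2cc(Cl)ccc2n1C`, gives 40 nM in this assay.
Compound 3, `CCn1c(C)c(C2=CCNCC2)c2cc(Cl)ccc21`, gives 100 nM in this assay.

Among these three, compound 3 gives the highest number, so it is the weakest binder shown; its nearest neighbour is compound 2 and its furthest is compound 1. Among the measured compounds shown here, the one comparison that changes a single point is a 2.5-fold higher number from compound 2 to compound 3 (0.40 log units; beyond the scatter), a modest rise on going from no chain to a methyl on the aromatic nitrogen.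

Compound 4, `CCCn1c(C)c(C2=CCNCC2)c2cc(Cl)ccc21`, is not yet measured. It differs from compound 3 by methyl in place of hydrogen on a saturated chain carbon, two bonds along the chain from an aromatic nitrogen, which is the same kind of change as between compound 2 and compound 3, only one bond further out. For the measured compounds named here, no measured pair shows this exact step, so the expectation leans on the step from compound 2 to compound 3 and on its modest size. A further small loss is expected, or at most a shift near the edge of the scatter, giving an expected 1.8-fold higher number from compound 3 to compound 4 (0.26 log units; within the scatter) in this assay.

Compound 4 is therefore estimated at 180 nM, in a range from 70 nM to 450 nM.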

Compound 4, half-maximal inhibitory concentration: 80 nM
The estimate for compound 4 lay 2.3-fold (0.35 log units) above the measured number; the range from low to high includes it.
By their numbers in this assay, from the lowest: compound 1; then compounds 2, 4 and 3 (each within the scatter of the next, the first and the last beyond it).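

Going from ethyl to propyl on the aromatic nitrogen gives a 1.3-fold lower number from compound 3 to compound 4 (0.10 log units; within the scatter) in this assay and so does not separate the two compounds: one further methyl at this place, two bonds along the chain, brings no change that can be told from the usual scatter. Starting from the methyl chain, the step to ethyl is a 2.5-fold higher number from compound 2 to compound 3 (0.40 log units; beyond the scatter) while the step to propyl is a 2.0-fold higher number from compound 2 to compound 4 (0.30 log units; within the scatter) and so, among compounds 2, 3 and 4, the number does not climb steadily as the chain grows, and the rise beyond the scatter seen with ethyl does not carry on to propyl. No measurement shown here accounts for this behaviour.

The compounds shown leave open what a longer chain such as butyl would do on this nitrogen, and whether the numbers would stay in the same band or start to move again. They also leave open how a branched isopropyl group, a benzyl group, or a chain ending in an amine or a carboxylic acid would compare with these straight chains.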